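The source may report more compounds than this note shows. Statements on the series, on what has been measured and on what is new or still open speak of the compounds shown alone.

Measured so far in a functional assay on the whole organism for agonist activity, with Mus musculus as the target; a higher number here means that more compound is needed for the effect, a lower number that less compound is needed:

compound 1, `COC(=O)N(C)C(C)C#CCN1CCCC1`: 9.7 mg/kg
compound 2, `COC(=O)N(C)C(C)C#CCn1ccnc1`: 6.6 mg/kg
compound 3, `CC(C#CCN1CCCC1)N1CCN(C)C1=O`: for compound 3 only a limit of this assay is known, > 30 mg/kg

Compound 2 differs from compound 1 by 1H-imidazol-1-yl in place of pyrrolidin-1-yl on a saturated chain carbon bound to a triple-bonded carbon. The step is a 1.5-fold lower number from compound 1 to compound 2 (0.17 log units; within the scatter), so the two values stand within the scatter of each other.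

Compound 3 carries a different core from compound 1; how the two cores differ is not broken down here. Of the three values shown, (the limit of > 30 mg/kg in this assay, at which 1 of the 3 values shown sits), and compound 3 is the one sitting there.

Compound 4, `CC(C#CCn1ccnc1)N1CCN(C)C1=O`, is not yet measured. It differs from compound 3 by 1H-imidazol-1-yl in place of pyrrolidin-1-yl on a saturated chain carbon bound to a triple-bonded carbon. The place is the same word for word as in the step from compound 1 to compound 2, so this is the same change, made on the core of compound 3.

Since the measured step gave a 1.5-fold lower number from compound 1 to compound 2 (0.17 log units; within the scatter), the expected step is a step that the limit leaves unreadable from compound 3 to compound 4, that is, little movement in this assay. Compound 4 is therefore estimated at 35 mg/kg, with a range of 15 mg/kg to 100 mg/kg, and it is expected that this assay may again report only a limit for compound 4.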

Compound 4, dose for half-maximal effect: 97 mg/kg
For compound 4 the middle estimate is 2.8-fold (0.44 log units) below the measured one; measured number inside the range.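

In this assay compound 3 is known only as a limit (> 30 mg/kg). The step to compound 4 therefore cannot be read, and no size can be given for 1H-imidazol-1-yl in place of pyrrolidin-1-yl on this core. On these data alone, it remains open whether this exchange on the core of compound 3 stays within the scatter, as it does from compound 1 to compound 2.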